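The source may hold more compounds than are shown below. What is called first, only, known or untested is meant among the compounds shown, and "the series" means these compounds.

Measured compounds in a toxicity assay on MCF-10A cells (Homo sapiens) for cytotoxicity, read by MTT assay, with a stated time of 48 h; a lower number here means a stronger inhibitor, a higher number a weaker inhibitor:

compound 1 `O=C(/C=C/c1ccc2c(c1)B(O)OC2)c1cccnc1`: 34400 nM
compound 2 `Cn1cccc1C(=O)/C=C/c1ccc2c(c1)B(O)OC2`: a limit of the assay, > 100000 nM

Compound 2 stands at the limit of the assay; no number is known for it, only that it sits at the limit of > 100000 nM in this assay, at which 1 of the 2 values shown sits. Among the compounds with values here, the one step measured so far, an at least 2.9-fold higher number from compound 1 to compound 2 (0.46 log units; beyond the scatter), shows that exchanging the aryl group on the carbonyl carbon moved the number upward by at least a modest amount, beyond the scatter.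

Compound 3 `O=C(/C=C/c1ccc2c(c1)B(O)OC2)c1ccc(F)cc1` differs from compound 2 by 4-fluorophenyl in place of 1-methyl-1H-pyrrol-2-yl on a carbonyl carbon. Within the data shown here, no measured pair covers this exact exchange; the only step that bears on it is the one from pyridin-3-yl to 1-methyl-1H-pyrrol-2-yl, which moved the number up to the limit. Whether 4-fluorophenyl returns the number toward that of compound 1 or leaves it at the limit cannot be read from the two compounds.

Compound 3 is expected to remain a weak inhibitor, with a step of about an at least 1.6-fold lower number from compound 2 to compound 3 (0.22 log units; that floor lies within the scatter) relative to compound 2, the estimate being 60000 nM with a range from 20000 nM to 150000 nM.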

Compound 3, half-maximal inhibitory concentration: 11800 nM
Compound 3: middle estimate off by 5.1-fold (0.71 log units), on the high side, outside the stated range (below it).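

In this assay the group on the carbonyl carbon now moves the number in both directions from pyridin-3-yl: the earlier step went only upward, while 4-fluorophenyl in its place gives the opposite result (a 2.9-fold lower number from compound 1 to compound 3 (0.46 log units; beyond the scatter)). Against 1-methyl-1H-pyrrol-2-yl, the same 4-fluorophenyl group gives a larger separation (an at least 8.4-fold lower number from compound 2 to compound 3 (0.92 log units; beyond the scatter)), and this size is only a floor, so compound 3 has the lowest number of the three, with both of its steps printed as beyond the scatter. Compound 2 remains a limit of the assay and not a number, which leaves the full span at this position unknown: the limit of > 100000 nM in this assay, at which 1 of the 3 values shown sits.

The compounds shown do not separate the contribution of the fluorine from that of the six-membered carbon ring, a question that plain phenyl or 4-chlorophenyl on the carbonyl carbon would address. As far as these compounds go, how an amine or a carboxylic acid on that aromatic ring would shift the number also remains open, as does whether the order of these groups would hold on a different core.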